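From Isopropyl to Cyclopropyl on the Aromatic Ring

The source may report more compounds than this note shows. Statements on the series, on what has been measured and on what is new or still open speak of the compounds shown alone.

Of the compounds shown here, three sharing one core have been measured in a functional assay (mast cells) for inhibition, with Rattus norvegicus as the target; on this read-out lower numbers stand for an effect already at smaller amounts and higher numbers for an effect only at larger amounts of compound. Compound 1 (`COc1ccc(N/N=C2\CCC(C)n3c2ncc(C(=O)O)c3=O)cc1`) gives a value of 128000 nM and compound 2 (`CC1CC/C(=N\Nc2ccc([N+](=O)[O-])cc2)c2ncc(C(=O)O)c(=O)n21`) gives 8900 nM in the same test. Compound 3 (`CC(C)c1ccc(N/N=C2\CCC(C)n3c2ncc(C(=O)O)c3=O)cc1`) stands lowest of the three, at 1200 nM in that read-out. Compound 4 (`CC1CC/C(=N\Nc2ccc(C3CC3)cc2)c2ncc(C(=O)O)c(=O)n21`) departs from compound 3 in one place, with cyclopropyl in place of isopropyl on an aromatic carbon.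

Within the data shown here, three measured steps concern that same place. Methoxy to nitro gave a 14-fold lower number from compound 1 to compound 2 (1.16 log units; beyond the scatter), methoxy to isopropyl gave a 110-fold lower number from compound 1 to compound 3 (2.03 log units; beyond the scatter), and nitro to isopropyl gave a 7.4-fold lower number from compound 2 to compound 3 (0.87 log units; beyond the scatter). These steps show that the place matters, but none of them involves cyclopropyl, and each exchanges isopropyl or its predecessor for a group containing atoms other than carbon. The new change stays among carbon-only groups, so a much smaller step is expected, with no change beyond the scatter in this assay. The expected step is a 1.3-fold higher number from compound 3 to compound 4 (0.10 log units; within the scatter) in this estimate. For compound 4 the estimated value is 1500 nM, with an expected range from 500 nM to 5000 nM.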

Compound 4, half-maximal effective concentration: 1000 nM
The estimate for compound 4 lay 1.5-fold (0.18 log units) above the measured number; the range from low to high includes it.
By their numbers in this assay, from the lowest: compounds 4 and 3 (each within the scatter of the next); then compound 2; then compound 1.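

In this assay, replacing isopropyl with cyclopropyl keeps the same count of heavy atoms but adds a three-membered ring, and it gave a 1.2-fold lower number from compound 3 to compound 4 (0.08 log units; within the scatter), so adding this ring on the aromatic carbon para to a large group left the number within the scatter. Cyclopropyl also gave an 8.9-fold lower number from compound 2 to compound 4 (0.95 log units; beyond the scatter) and a 130-fold lower number from compound 1 to compound 4 (2.11 log units; beyond the scatter), which shows that among these compounds the low number is not confined to isopropyl but is shared by a second group of carbon only. No evidence is available that bears on this result.

As far as these compounds go, how an amine, a longer chain such as butyl or a larger carbon ring such as cyclohexyl would fare at this place remains open. Whether isopropyl and cyclopropyl would also stay this close on a different core is open as well.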